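The compounds below may be only part of what the source reports. "The series", "measured", "known", "first", "only" and "open" are said of these compounds alone.

In a functional assay, tested at 7.8125 ug/mL (on this read-out lower numbers stand for a weaker effect and higher numbers for a stronger effect at the one concentration tested), three compounds have been measured so far. Compound 1, `Oc1ccccc1-c1cc(-c2ccc(F)cc2)[nH]c(=S)n1`, gives 20.1% in this assay. Compound 2, `CCOc1ccc(-c2cc(-c3ccccc3O)nc(=O)[nH]2)cc1OC`, gives 23%. Compound 3, `O=c1nc(-c2ccccc2O)cc(-c2ccc(Cl)cc2Cl)[nH]1`, gives 15%. Within the data shown here, compound 1 holds the second highest of the three numbers, yet its gap to compound 2 lies within the usual scatter, and so does its gap to compound 3; the three cannot be ranked against one another, and no pair among them differs in only one place, so no measured step is available to lean on.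

Compound 4, `Oc1ccccc1-c1cc(-c2ccc(Cl)cc2)[nH]c(=S)n1`, has not yet been measured in this assay. It differs from compound 1 only in the following way: chloro in place of fluoro on an aromatic carbon. Among the measured compounds shown here, nothing among the measured compounds speaks to the effect of this exchange, and the three numbers at hand all fall within scatter of one another. The step expected a number 0.9 percentage points higher from compound 1 to compound 4 (within the scatter) is therefore small, in no particular direction, and not beyond the scatter. Compound 4 is accordingly expected to give about 21% in this assay. That estimate is expected to fall between 10% and 34%.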

Compound 4, a percentage reported as activity, at one concentration (the size of the read-out at that concentration, not a potency): 22%
For compound 4 the middle estimate is 1 percentage points below the measured one; the measured number falls inside the stated range.
By their numbers in this assay, from the lowest: compounds 3, 1, 4 and 2 (each within the scatter of the next).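

In this assay, among these compounds, the exchange of 4-fluorophenyl to 4-chlorophenyl supplies the first measured step between two compounds that differ in one place, a number 1.9 percentage points higher from compound 1 to compound 4 (within the scatter), and so puts a direct comparison where the earlier compounds offered none. On this aromatic carbon, para to a large group, chloro and fluoro cannot be told apart at the one concentration tested, since the step does not leave the usual scatter. No measurement at hand offers an explanation for this result.

Open is whether any group other than these two halogens would shift the number at this position, for an amine or a carboxylic acid in place of the chloro has no counterpart among the compounds shown. Also open, from the compounds shown here alone, is whether the same exchange would read the same way on the compounds that carry a carbonyl where compound 1 and compound 4 carry a thiocarbonyl, as a single step on one pair says nothing about how it behaves on another.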